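Swapping fluoro for methoxy on the pendant phenyl ring

The source may report more compounds than this note shows. Statements on the series, on what has been measured and on what is new or still open speak of the compounds shown alone.

Measured so far in a functional assay on MDA-MB-231 cells (Homo sapiens) for cytotoxicity, read by sulforhodamine B assay, with a stated time of 48 h; a higher number here means a weaker inhibitor of growth, a lower number a stronger inhibitor of growth:
Compound 1, `COc1ccc2nc(-c3ccc(-n4c(C)ccc4-c4cc(OC)c(OC)c(OC)c4)cc3)sc2c1`, gives 1760 nM.
Compound 2, `COc1cc2nc(-c3ccc(-n4c(C)ccc4-c4ccc(C)cc4)cc3)sc2c(OC)c1OC`, gives 4140 nM.
Compound 3, `COc1cc2nc(-c3ccc(-n4c(C)ccc4-c4ccc(F)cc4)cc3)sc2c(OC)c1OC`, gives 3940 nM.

Compound 3 stands second highest of the three numbers in this assay. Its nearest neighbour is compound 2, which sits within the scatter of it; compound 1, which carries a different core and a different pendant ring, sits furthest away, and that gap lies beyond the scatter.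

The new compound, compound 4, `COc1ccc(-c2ccc(C)n2-c2ccc(-c3nc4cc(OC)c(OC)c(OC)c4s3)cc2)cc1`, differs from compound 3 in one place: methoxy in place of fluoro on an aromatic carbon.

Going by the values given here, only one measured step shares the same site, and it reads a 1.1-fold lower number from compound 2 to compound 3 (0.02 log units; within the scatter). That step exchanged methyl for fluoro and left the number essentially where it was. Nothing measured here exchanges fluoro for methoxy, so the direction of the present change is not shown by any pair. Among the compounds with values here, with the one nearby step flat, the expectation for compound 4 is a number close to that of compound 3, with no move beyond the scatter, as the estimated step of a 1.1-fold lower number from compound 3 to compound 4 (0.05 log units; within the scatter) expresses.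

Compound 4 is therefore expected to give about 3500 nM in this assay, within a range from 1500 nM to 8000 nM.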

Compound 4, concentration for 50% growth inhibition: 2240 nM
Compound 4: the middle estimate sits 1.6-fold (0.19 log units) above what was measured, and the stated range covers the measured number.
By their numbers in this assay, from the lowest: compounds 1, 4, 3 and 2 (each within the scatter of the next, the first and the last beyond it).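

In this assay the change from 4-fluorophenyl to 4-methoxyphenyl gives a 1.8-fold lower number from compound 3 to compound 4 (0.25 log units; within the scatter) and methoxy in place of methyl at the same place gives a 1.8-fold lower number from compound 2 to compound 4 (0.27 log units; within the scatter) and so neither step leaves the scatter. Methyl, fluoro and methoxy have now all been read on this aromatic carbon, para to a large group, and with the rest of the molecule held constant, the three compounds cannot be told apart, even though methoxy brings one more heavy atom than fluoro and a hydrogen-bond acceptor. No independent measurement is available to explain this flat reading.

Still open, from the compounds shown here alone, is whether any group at this place can move the number beyond the scatter, for example an amine, a carboxylic acid or a longer chain such as butoxy. Compound 1 differs from compound 4 in more than one place, so it cannot show whether these small steps would stay the same on the core of compound 1.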